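The source may hold more compounds than are shown below. What is called first, only, known or untested is meant among the compounds shown, and "the series" means these compounds.

Measured compounds in an ADME assay for permeability, using PAMPA, at pH 7.4; on this read-out higher numbers stand for higher permeability and lower numbers for lower permeability:
- compound 1, `Cc1cc(NC(=O)Nc2ccccc2C(F)(F)F)c2ccccc2n1`, gives 945 10^-6 cm/s
- compound 2, `Cc1cc(NC(=O)Nc2ccc(F)c(F)c2)c2ccccc2n1`, gives 478 10^-6 cm/s

Compound 1 holds the highest of the two numbers in this assay; compound 2 sits closest, and the gap between them falls within the usual scatter, so the two are read as equivalent. Going by the values given here, no step between measured compounds is available for this pair.

The compound to be measured is compound 3, `Cc1cc(NC(=O)Nc2ccccc2N)c2ccccc2n1`. Relative to compound 1 the change is amino in place of trifluoromethyl on an aromatic carbon, with the new group placed ortho to a large group on the carbon-only six-membered aromatic ring.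

Nothing in the measured set covers this exchange directly. The expectation is still a downward step in this assay beyond the scatter, of moderate size, expressed as a 3.2-fold lower number from compound 1 to compound 3 (0.50 log units; beyond the scatter). On that basis compound 3 is estimated at 300 10^-6 cm/s, with a range from 100 10^-6 cm/s to 800 10^-6 cm/s.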

Compound 3, apparent permeability: 300 10^-6 cm/s
The estimate for compound 3 equals the measured number at the digits printed; the measured number falls inside the stated range.
By their numbers in this assay, from the lowest: compounds 3, 2 and 1 (each within the scatter of the next, the first and the last beyond it).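

Going by these compounds alone, compound 3 supplies the first single-place step in this assay, where amino in place of trifluoromethyl on an aromatic carbon, ortho to a large group, gives a 3.2-fold lower number from compound 1 to compound 3 (0.50 log units; beyond the scatter), a modest change. This exchange swaps four heavy atoms without a hydrogen-bond donor or acceptor for one heavy atom that counts as both, and compound 3 still reads 300 10^-6 cm/s in this series. No measurement available here accounts for the step.

A methyl, a methoxy or a dimethylamino group at this same place would show whether the step tracks the amino hydrogens, the nitrogen or the loss of trifluoromethyl. On these data alone, whether the same exchange gives a step of similar size elsewhere on this ring remains open.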